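The source may hold more compounds than are shown below. What is called first, only, known or untested is meant among the compounds shown, and "the series" means these compounds.

Measured compounds in an ADME assay on HCT-116 cells (Homo sapiens) for cytotoxicity, read by CellTiter-Glo, with a stated time of 72 h; on this read-out lower numbers stand for stronger inhibition and higher numbers for weaker inhibition:
compound 1 `CC1CCN(C2CCN(S(=O)(=O)c3cccc(-c4ccccc4C(F)(F)F)c3)CC2)CC1` — > 5000 nM
compound 2 `Cc1cc(C)c(S(=O)(=O)N2CCC(N3CCC(C)CC3)CC2)c(C)c1` — > 5000 nM
compound 3 `COc1ccc(OC)c(S(=O)(=O)N2CCC(N3CCC(C)CC3)CC2)c1` — > 5000 nM

Compound 2 stands at > 5000 nM in this assay, which is a limit of the assay and not a number. Compound 1 likewise gives only a limit, > 5000 nM. Compound 3 gives only a limit, > 5000 nM. In this assay, (the limit of > 5000 nM in this assay, at which 3 of the 3 values shown sit), so no value within the series orders compound 2 against the others.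

Compound 4 `Cc1cc(C)c(S(=O)(=O)N2CCC(N3CCCCC3)CC2)c(C)c1` follows from compound 2 by hydrogen in place of methyl on a saturated ring carbon. For the measured compounds named here, no pair of measured compounds shows this change, so no measured step guides it. The expected step that the limit leaves unreadable from compound 2 to compound 4 is none beyond the scatter. Compound 4 is therefore estimated at 8000 nM, with an expected range of 3000 nM to 30000 nM, most likely again reported only as a limit.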

Compound 4, half-maximal inhibitory concentration: > 5000 nM
Compound 4: only a limit was reported (the forecaster's own chance of this, stated with the estimate: 85%); the middle value is on the limit's open side.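

Compound 2 and compound 4 both give only a limit, so the change from 4-methylpiperidin-1-yl to piperidin-1-yl yields no readable step: the limit of > 5000 nM in this assay, at which 4 of the 4 values shown sit.

The compounds shown leave open which structural change, if any, would give an actual number in this assay.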